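The source may hold more compounds than are shown below. What is called first, only, known or untested is meant among the compounds shown, and "the series" means these compounds.

In an ADME assay on L1210/0 cells (Mus musculus) for cytotoxicity, with a stated time of 48 h (on this read-out higher numbers stand for weaker inhibition and lower numbers for stronger inhibition), compound 3 (`C[S+]([O-])c1cn([C@H]2C[C@H](O)[C@@H](CO)O2)c(=O)[nH]c1=O`) gives > 200000 nM as a limit and not as a number. Compound 1 (`COCC#Cc1cn([C@H]2C[C@H](O)[C@@H](CO)O2)c(=O)[nH]c1=O`) gives > 200000 nM as a limit too. Compound 2 (`O=c1[nH]c(=O)n([C@H]2C[C@H](O)[C@@H](CO)O2)cc1C#CCCCO`) gives > 200000 nM as a limit as well. Compound 3 therefore stands level with the other two, and the limit of > 200000 nM in this assay, at which 3 of the 3 values shown sit, is all that the numbers show so far.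

The change to compound 4 (`CC#Cc1cn([C@H]2C[C@H](O)[C@@H](CO)O2)c(=O)[nH]c1=O`) is this: a group of 3 heavy atoms (3 carbon; no ring) in place of a group of 3 heavy atoms (1 carbon, 1 oxygen, 1 sulfur; no ring), on an aromatic carbon on the shared core. A prop-1-yn-1-yl group, with 1 triple bond outside aromatic rings, enters on the aromatic carbon in place of the group that leaves.

Among the compounds with values here, three measured steps bear on it: a step that the two limits leave unreadable from compound 1 to compound 3 and a step that the two limits leave unreadable from compound 2 to compound 3 and also a step that the two limits leave unreadable from compound 1 to compound 2 as the third. Compound 1 and compound 2 carry a triple bond on that aromatic carbon, as compound 4 does, but none of these steps has a readable size. They offer no measured size to carry over, so only a modest move towards stronger inhibition, or none at all, is expected in this assay and another limit is about as likely as a number. The expected step is an at least 2.0-fold lower number from compound 3 to compound 4 (0.30 log units; that floor lies within the scatter) on this estimate. For compound 4 the estimated value is 100000 nM within an expected range from 15000 nM to 300000 nM in this read-out.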

Compound 4, half-maximal inhibitory concentration: > 200000 nM
Compound 4: no number, only a limit; the forecaster's own chance of this, stated with the estimate: 50%; middle value at least 2.0-fold (0.30 log units) from the limit.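

In this assay compound 4 gives > 200000 nM, a limit and not a number. Its steps from compound 1, compound 2 and compound 3 therefore cannot be read. The values show only this: the limit of > 200000 nM in this assay, at which 4 of the 4 values shown sit. The compounds shown leave open whether any change on the shared core gives a number rather than a limit.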